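The source may hold more compounds than are shown below. What is called first, only, known or untested is meant among the compounds shown, and "the series" means these compounds.

Compound 2 `O=C(Nc1cccc(C(=O)O/N=C2\CCCc3onc(-c4ccccc4F)c32)c1)c1cccc(F)c1` stands at the edge of what a functional assay on MCF7 cells (Homo sapiens) for antiproliferative activity, read by MTT assay, with a stated time of 72 h (on this read-out lower numbers stand for stronger inhibition and higher numbers for weaker inhibition), can report: its result is a limit, > 25000 nM, and not a number. Its nearest measured neighbour is compound 1 `O=C(Nc1cccc(C(=O)O/N=C2\CCCc3onc(-c4cccc(F)c4)c32)c1)c1cccc(F)c1`, which in this assay gives 4700 nM. For the measured compounds named here, the only step between measured compounds is an at least 5.3-fold higher number from compound 1 to compound 2 (0.72 log units; beyond the scatter), and its size rests on (the limit of > 25000 nM in this assay, at which 1 of the 2 values shown sits), so the true gap from compound 1 to compound 2 may be wider than stated. Compound 3 `COc1ccc(-c2noc3c2/C(=N/OC(=O)c2cccc(NC(=O)c4cccc(F)c4)c2)CCC3)cc1OC` differs from compound 2 at the same carbon of the shared core: 3,4-dimethoxyphenyl in place of 2-fluorophenyl on an aromatic carbon. Going by the values given here, the step from compound 1 to compound 2 shows that exchanging the aryl group on this carbon can move the read-out beyond the scatter, yet no measured pair shows what a 3,4-dimethoxyphenyl does there, so both the direction and the size of the new step are open. Compound 3 is therefore estimated at 10000 nM, within a range from 2000 nM to 50000 nM, which would mean a step of an at least 2.5-fold lower number from compound 2 to compound 3 (0.39 log units; beyond the scatter) back into the measurable range.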

Compound 3, half-maximal inhibitory concentration: > 25000 nM
Compound 3: no number, only a limit; the forecaster's own chance of this, stated with the estimate: 40%; at least 2.5-fold (0.39 log units) between middle value and limit.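

In this assay compound 3 gives > 25000 nM, which is a limit of the assay and not a number, so a second, quite different aryl group on this carbon ends at the same limit as the 2-fluorophenyl. Exchanging the 3-fluorophenyl for the 3,4-dimethoxyphenyl gives an at least 5.3-fold higher number from compound 1 to compound 3 (0.72 log units; beyond the scatter), which runs in the same direction as the exchange for the 2-fluorophenyl and lies beyond the scatter, so among the three compounds shown only compound 1, with its 3-fluorophenyl, gives a number in this assay. The step between compound 2 and compound 3 cannot be read, and how far each lies from compound 1 stays unknown, because both results rest on the same limit: the limit of > 25000 nM in this assay, at which 2 of the 3 values shown sit.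

The compounds shown leave open whether the measurable result of compound 1 belongs to the 3-fluorophenyl in particular or would also appear with other groups on this carbon, such as an unsubstituted phenyl or a pyridyl ring. They also leave open whether any group at this position could give a lower number than compound 1 does.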